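Sulfonamide nitrogen swaps near the assay limit

The source may hold more compounds than are shown below. What is called first, only, known or untested is meant among the compounds shown, and "the series" means these compounds.

In a functional assay on DU-145 cells (Homo sapiens) for antiproliferative activity, read by MTT assay, with a stated time of 72 h (a higher number here means a weaker inhibitor, a lower number a stronger inhibitor), compound 1 `Cc1cccc(N(C)S(=O)(=O)C2CC3OC2C(c2ccc(NC(=O)CCCCCCC(=O)O)cc2)=C3c2ccc(O)cc2)c1` gives > 100000 nM, which is a limit of the assay and not a number. Going by the values given here, compound 2 `CN(c1ccccc1Cl)S(=O)(=O)C1CC2OC1C(c1ccc(NC(=O)CCCCCCC(=O)O)cc1)=C2c1ccc(O)cc1` gives 73500 nM, the only true number so far, so it cannot yet be ranked against a second measured value. Among the compounds with values here, the sole measured step is an at least 1.3-fold lower number from compound 1 to compound 2 (0.13 log units; that floor lies within the scatter), with 2-chlorophenyl in place of 3-methylphenyl on a sulfonamide nitrogen. The series also sits at the limit of > 100000 nM in this assay, at which 1 of the 2 values shown sits.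

Compound 3 `CCN(c1ccc(C)cc1)S(=O)(=O)C1CC2OC1C(c1ccc(NC(=O)CCCCCCC(=O)O)cc1)=C2c1ccc(O)cc1` brings (ethyl(4-methylphenyl)amino in place of (2-chlorophenyl)(methyl)amino on a sulfonyl sulfur), that is, ethyl(4-methylphenyl)amino in place of (2-chlorophenyl)(methyl)amino on a sulfonyl sulfur. The step to compound 2 is the only one that bears on this change, and it does not go beyond the scatter, so no step beyond the scatter is expected in this assay. The estimated step is a 1.2-fold higher number from compound 2 to compound 3 (0.06 log units; within the scatter). For compound 3 the expected value is 85000 nM, with an estimated range of 40000 nM to 170000 nM.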

Compound 3, half-maximal inhibitory concentration: 53500 nM
The estimate for compound 3 lay 1.6-fold (0.20 log units) above the measured number; the measured number falls inside the stated range.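

In this assay, the step of a 1.4-fold lower number from compound 2 to compound 3 (0.14 log units; within the scatter) gives the series a second true number, and it shows that exchanging (2-chlorophenyl)(methyl)amino for ethyl(4-methylphenyl)amino on the sulfonyl sulfur leaves the value unresolved from that of compound 2. The comparison with the limit compound adds little, as the step reads an at least 1.8-fold lower number from compound 1 to compound 3 (0.27 log units; that floor lies within the scatter), so no substituent at this position is separated from the others yet. Compound 1 remains a limit and not a number: the limit of > 100000 nM in this assay, at which 1 of the 3 values shown sits.

The ethyl and the 4-methylphenyl enter together, so the pair cannot assign any share of the step to either part. Still open, as far as these compounds go, is whether a hydroxamic acid in place of the carboxylic acid, or a shorter chain, would move the values beyond the scatter.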